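Thiophen-2-yl in place of 2-chlorophenyl on the shared core

The source may report more compounds than this note shows. Statements on the series, on what has been measured and on what is new or still open speak of the compounds shown alone.

In a functional assay on MOLT-4 cells (Homo sapiens) for cytotoxicity, read by CCK-8 assay, with a stated time of 24 h (a higher number here means a weaker inhibitor, a lower number a stronger inhibitor), compound 1 `C=CC(=O)N1C(=O)CC(c2ccc(Br)cc2)Sc2ccccc21` gives 106000 nM and compound 2 `C=CC(=O)N1C(=O)CC(c2ccccc2Cl)Sc2ccccc21` gives 80300 nM as its reading, which places compound 2 within the scatter of compound 1. Compound 3 `C=CC(=O)N1C(=O)CC(c2cccs2)Sc2ccccc21` carries thiophen-2-yl in place of 2-chlorophenyl on a saturated ring carbon. For the measured compounds named here, only one measured step bears on this carbon (a 1.3-fold lower number from compound 1 to compound 2 (0.12 log units; within the scatter)) and it is small, so no change beyond the scatter is expected in this assay for this swap. The estimated step is a 1.1-fold higher number from compound 2 to compound 3 (0.05 log units; within the scatter) for this swap. Compound 3 is expected to read 90000 nM with an estimated range from 40000 nM to 200000 nM in all.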

Compound 3, half-maximal inhibitory concentration: 557000 nM
For compound 3 the middle estimate is 6.2-fold (0.79 log units) below the measured one; measured number outside the range, above it.
By their numbers in this assay, from the lowest: compounds 2 and 1 (each within the scatter of the next); then compound 3.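

The two phenyl groups alone made this saturated ring carbon look indifferent to what it carries, but the ring itself turns out to matter. In this assay, thiophen-2-yl gives a 6.9-fold higher number from compound 2 to compound 3 (0.84 log units; beyond the scatter) and a 5.3-fold higher number from compound 1 to compound 3 (0.72 log units; beyond the scatter), so the compound weakens whichever phenyl group is replaced. Nothing measured here gives a reason for this loss. From the compounds shown here alone, it remains open whether the loss belongs to thiophen-2-yl alone or extends to other five-membered aromatic rings such as furan-2-yl. Going by these compounds, whether an unsubstituted phenyl reads like compound 1 and compound 2 is also open.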